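Compound 4 Against Three Readings Stuck at a Limit

This account rests on a few compounds, and the source may have more. Where it says the series, first, only, none or still open, it means among the compounds named here.

Measured in a functional assay on MDA-MB-231 cells (Homo sapiens) for antiproliferative activity, read by CCK-8 assay, with a stated time of 48 h; a lower number here means a stronger inhibitor, a higher number a weaker inhibitor:
- compound 1 `C=CC(=O)NCCOc1ccc(Oc2c(-c3ccc(F)cc3)sc3cc(O)ccc23)cc1`: > 50000 nM (a limit)
- compound 2 `C=C(C)C(=O)NCCOc1ccc(Oc2c(-c3ccc(F)cc3)sc3cc(O)ccc23)cc1`: > 50000 nM (a limit)
- compound 3 `C/C=C/C(=O)N1CC(Oc2ccc(Oc3c(-c4ccc(F)cc4)sc4cc(O)ccc34)cc2)C1`: > 50000 nM (a limit)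

Compound 3 has no exact number in this assay, only the limit > 50000 nM. It shares that position with both other compounds, as the limit of > 50000 nM in this assay, at which 3 of the 3 values shown sit, shows.

Compound 4 `CN(C)C(=O)/C=C/CNCCOc1ccc(Oc2c(-c3ccc(F)cc3)sc3cc(O)ccc23)cc1` has not yet been measured. In it, 2-((3-(dimethylcarbamoyl)prop-2-en-1-yl)amino)ethyl takes the place of 1-((prop-1-en-1-yl)carbonyl)azetidin-3-yl on an oxygen on an aromatic ring: 2-((3-(dimethylcarbamoyl)prop-2-en-1-yl)amino)ethyl in place of 1-((prop-1-en-1-yl)carbonyl)azetidin-3-yl on an oxygen on an aromatic ring.

The measured steps offer little guidance. They are a step that the two limits leave unreadable from compound 1 to compound 2, a step that the two limits leave unreadable from compound 1 to compound 3 and a step that the two limits leave unreadable from compound 2 to compound 3, so none has a size that could be carried over to this change. No direction can be drawn from them, and weak activity is expected for compound 4 because of the limit of > 50000 nM in this assay, at which 3 of the 3 values shown sit. The expected change is a number no higher from compound 3 to compound 4 (the limit leaves the size open). For compound 4 the estimate is 50000 nM, with an expected range from 15000 nM to 100000 nM.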

Compound 4, half-maximal inhibitory concentration: > 50000 nM
Compound 4: no number, only a limit; the forecaster's own chance of this, stated with the estimate: 65%; the middle value sits exactly at the limit.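

In this assay compound 4 gives > 50000 nM as a limit and not a number. Among the compounds shown here, no step from compound 1, compound 2 or compound 3 to compound 4 can be read. The compounds shown leave open which structural change, if any, alters activity, because none has an exact number: the limit of > 50000 nM in this assay, at which 4 of the 4 values shown sit.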